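This account rests on a few compounds, and the source may have more. Where it says the series, first, only, none or still open, it means among the compounds named here.

Compound 1 `Cc1ccccc1S(=O)(=O)Nc1ccc2oc(-c3ccccc3)nc2c1`: 57000 nM; compound 2 `O=S(=O)(Nc1ccc(-c2nc3ccccc3o2)cc1)c1cccc(O)c1`: > 100000 nM; compound 3 `CCc1ccc(S(=O)(=O)Nc2ccc(-c3nc4ccccc4o3)cc2)cc1`: 82000 nM.

In an ADME assay on HEK293 cells (Homo sapiens) for cytotoxicity, read by resazurin assay, with a stated time of 48 h (a lower number here means that less compound is tolerated, a higher number that more compound is tolerated), compound 1 gives 57000 nM, and compound 3, with 82000 nM, lies within the scatter of it. For compound 2 the reading is a limit of the assay, > 100000 nM (the limit of > 100000 nM in this assay, at which 1 of the 3 values shown sits). Compound 4 `O=S(=O)(Nc1ccc2oc(-c3ccccc3)nc2c1)c1ccccc1O` is not yet measured; it differs from compound 1 by hydroxy in place of methyl on an aromatic carbon. For the measured compounds named here, the only measured step that involves a hydroxy is an at least 1.2-fold lower number from compound 2 to compound 3 (0.08 log units; that floor lies within the scatter), which runs the other way, from hydroxy to alkyl, and stays within the scatter. Read in reverse it points toward a modestly higher number for compound 4, with a real chance that the assay returns only a limit. Compound 4 is therefore expected at 80000 nM, between 40000 nM and 160000 nM, a step of a 1.4-fold higher number from compound 1 to compound 4 (0.15 log units; within the scatter).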

Compound 4, half-maximal cytotoxic concentration: 33000 nM
Beside the measured number, compound 4's estimate is 2.4-fold (0.38 log units) above it; measured number below the stated range.
By their numbers in this assay, from the lowest: compounds 4, 1 and 3 (each within the scatter of the next, the first and the last beyond it). At a limit, above all of these: compound 2.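

For the compounds shown here, this is the first direct reading of hydroxy in place of methyl on an aromatic carbon ortho to a large group: for the change from 2-methylphenyl to 2-hydroxyphenyl, this assay shows a 1.7-fold lower number from compound 1 to compound 4 (0.24 log units; within the scatter) and returns a number, not a limit. At this place, then, the hydroxy compound stays within the scatter of the methyl compound. Nothing measured here explains the result.

Going by these compounds, whether an amine or a carboxylic acid at this place would also stay within the scatter remains open. So does whether hydroxy and methyl would compare in the same way elsewhere on this ring.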